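Chloro for hydrogen on the second fused core

This account rests on a few compounds, and the source may have more. Where it says the series, first, only, none or still open, it means among the compounds named here.

Of the compounds shown here, three have been tested in a functional assay on M14 cells (Homo sapiens) for cytotoxicity, read by sulforhodamine B assay, with a stated time of 48 h; on this read-out lower numbers stand for stronger inhibition of growth and higher numbers for weaker inhibition of growth. Compound 1 `ClCc1ccccc1Cn1cnc2c(Cl)nc(Cl)nc21` gives 2810 nM in this assay. Compound 2 `ClCc1ccccc1Cn1cnc2c(Cl)ncnc21` gives 3710 nM. Compound 3 `ClCc1ccccc1Cn1cnc2ncnc(Cl)c21` gives 5120 nM, and its values and those of compounds 1 and 2 all lie within the scatter of one another, so no order among the three is claimed.

Compounds 1 and 2 share a core and differ at one place: chloro in place of hydrogen on an aromatic carbon. This change produced a 1.3-fold lower number from compound 2 to compound 1 (0.12 log units; within the scatter), a step that does not stand out from repeat measurement noise.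

Compound 3 has the same atoms as compound 2 joined differently; the difference between the two cores is not broken down here. Compound 4 `ClCc1ccccc1Cn1cnc2nc(Cl)nc(Cl)c21` is the still untested member built on the core of compound 3, and it differs from compound 3 by chloro in place of hydrogen on an aromatic carbon. The place of the entering chloro is described in the same words for both pairs, so the change from compound 3 to compound 4 is the same change that was made from compound 2 to compound 1.

Resting on that single precedent, the step from compound 3 to compound 4 in this assay is expected to be about a 1.3-fold lower number from compound 3 to compound 4 (0.12 log units; within the scatter), because the same change gave a 1.3-fold lower number from compound 2 to compound 1 (0.12 log units; within the scatter). Going by the values given here, on that basis compound 4 is estimated at 3900 nM in this assay, with the expected range running from 2000 nM to 7500 nM; only one earlier instance of the change is known, so the range is kept wide.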

Compound 4, concentration for total growth inhibition: 3460 nM
The estimate for compound 4 lay 1.1-fold (0.05 log units) above the measured number; the measured number falls inside the stated range.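

On the second core, chloro in place of hydrogen on an aromatic carbon gave a 1.5-fold lower number from compound 3 to compound 4 (0.17 log units; within the scatter) in this assay. Set beside the earlier instance of the same change, the two steps do not differ: the same change on two cores in this assay, a 1.3-fold lower number (0.12 log units; within the scatter) from compound 2 to compound 1 and a 1.5-fold lower number (0.17 log units; within the scatter) from compound 3 to compound 4, 1.1-fold (0.05 log units) apart, within the scatter of two such steps. This shows that, across these two cores, the change gives steps that cannot be told apart; it does not show that chloro has a real effect on growth inhibition on either core, as each step lies within the scatter, and two pairs set no rule for any other core.

The compounds shown leave open whether a group other than chloro at this place, such as an amine, a methoxy group or a longer chain, would give a step beyond the scatter. Going by these compounds, the chloromethyl group is also the same in all four compounds, so it remains open how the number would respond if it gave way to a hydroxymethyl group or a carboxylic acid.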